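The source may hold more compounds than are shown below. What is called first, only, known or untested is meant among the compounds shown, and "the series" means these compounds.

Measured in a functional assay on MCF7 cells (Homo sapiens) for cytotoxicity, read by MTT assay, with a stated time of 72 h; a higher number here means a weaker inhibitor of growth, a lower number a stronger inhibitor of growth:

Compound 1 `CCCCC[Se]c1nc(NCc2ccccc2)c2ccccc2n1`: 47100 nM
Compound 2 `CCCCC[Se]c1nc(N)c2cccnc2n1`: 53800 nM
Compound 3 `C[Se]c1nc(NCc2ccccc2)c2ccccc2n1`: 67000 nM

Compound 1 and compound 2 carry different cores; the difference between the two cores is not broken down here. Their values in this assay lie close together, and compound 3 lies close to both.

One structural change has a measured step: from compound 1 to compound 3, (hydrogen in place of butyl on a saturated chain carbon bound to a selenium atom). The step it made was a 1.4-fold higher number from compound 1 to compound 3 (0.15 log units; within the scatter).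

Compound 4 `C[Se]c1nc(N)c2cccnc2n1` is not yet measured. It stands to compound 2 as compound 3 stands to compound 1: hydrogen in place of butyl on a saturated chain carbon bound to a selenium atom. The two changes are the same, with the same place, and this change occurs twice among the compounds shown.

For compound 4 the step from compound 2 is expected to be a 1.3-fold higher number from compound 2 to compound 4 (0.11 log units; within the scatter), set beside a 1.4-fold higher number from compound 1 to compound 3 (0.15 log units; within the scatter); this rests on that single measured step and on the closeness of compound 2 to compound 1 in this assay. Compound 4 is therefore estimated at 70000 nM, with a range from 35000 nM to 140000 nM.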

Compound 4, concentration for total growth inhibition: > 100000 nM
Compound 4 was reported as a limit (the forecaster's own chance of this, stated with the estimate: 10%); middle value at least 1.4-fold (0.15 log units) away from the limit.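

In this assay compound 4 gives > 100000 nM, which is a limit of the assay and not a number. On these data alone, on the core of compound 2, hydrogen in place of butyl on a saturated chain carbon bound to a selenium atom gives an at least 1.8-fold higher number from compound 2 to compound 4 (0.26 log units; that floor lies within the scatter), and the true size of this step remains unknown. The earlier step and this floor both lie within the scatter, so the series neither shows that the change carries over unaltered from one core to the other nor shows that its size depends on the core: the same change on two cores in this assay, a 1.4-fold higher number (0.15 log units; within the scatter) from compound 1 to compound 3 and an at least 1.8-fold higher number (0.26 log units; that floor lies within the scatter) from compound 2 to compound 4; the limit leaves it open whether they differ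

As far as these compounds go, only the pentyl and methyl chains on selenium appear here, so the reading of a propyl chain or a longer chain such as octyl on either core stays open. Also open, from the compounds shown here alone, is how a chain ending in a hydroxyl group or a carboxylic acid would read in this assay.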